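Phenyl for methyl on a ring nitrogen of compound 3

This account rests on a few compounds, and the source may have more. Where it says the series, first, only, none or still open, it means among the compounds named here.

Three compounds of this series have been run in a functional assay on NSCLC cells (Homo sapiens) for inhibition; on this read-out higher numbers stand for weaker inhibition of growth and lower numbers for stronger inhibition of growth. Compound 1 `CN1CC2=C(N=C(S)NC2c2cccs2)/C(=C/c2cccs2)C1` stops at the limit of > 100000 nM. Compound 2 `COc1ccc(/C=C2\CN(C)CC3=C2N=C(S)NC3c2ccc(OC)cc2)cc1` gives 93600 nM. Compound 3 `CN1C/C(=C\c2cccs2)C2=NN(C)C(c3cccs3)C2C1` likewise stops at the limit of > 100000 nM. Compound 3 therefore stands at the limit of > 100000 nM in this assay, at which 2 of the 3 values shown sit, and carries no number of its own. Among the measured compounds shown here, compound 2 holds the only numbered value among the three. For the measured compounds named here, no step between two measured compounds is available, so no measured change can guide the next one. Compound 4 `CN1C/C(=C\c2cccs2)C2=NN(c3ccccc3)C(c3cccs3)C2C1` differs from compound 3 by phenyl in place of methyl on an amine nitrogen in a ring. The step of an at least 1.1-fold lower number from compound 3 to compound 4 (0.04 log units; that floor lies within the scatter) is expected to stay within the scatter. For compound 4 in this assay the estimate is 90000 nM, with a range from 40000 nM to 200000 nM.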

Compound 4, concentration for total growth inhibition: > 100000 nM
Compound 4 was reported as a limit (the forecaster's own chance of this, stated with the estimate: 60%); middle value at least 1.1-fold (0.04 log units) from the limit.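

Among the compounds shown here, compound 3 and compound 4 both stop at a limit, so no step between them can be read. The compounds shown leave open what phenyl in place of methyl on an amine nitrogen in a ring does to growth inhibition, because most values share one limit: the limit of > 100000 nM in this assay, at which 3 of the 4 values shown sit.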